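The compounds below may be only part of what the source reports. "The series", "measured", "known", "first", "only" and "open" are said of these compounds alone.

In a functional assay on NCI-H460 cells (Homo sapiens) for cytotoxicity, read by MTT assay, with a stated time of 68 h (a lower number here means a stronger inhibitor, a higher number a weaker inhibitor), compound 1 `Nc1cccc(-c2cccc(NC(=O)C(Cl)Cl)c2)c1` gives > 50000 nM, which is a limit of the assay. Compound 2 `Cc1cccc(-c2cccc(NC(=O)C(Cl)Cl)c2)c1` gives a measured 24300 nM. Compound 3 `O=C(Nc1cccc(-c2cccc(Cl)c2)c1)C(Cl)Cl` gives > 50000 nM, also a limit. That places compound 3 at the limit of > 50000 nM in this assay, at which 2 of the 3 values shown sit.

Compound 4 `O=C(Nc1cccc(-c2cccc(NC(=O)C(Cl)Cl)c2)c1)C(Cl)Cl` carries ((dichloromethyl)carbonyl)amino in place of chloro on an aromatic carbon, meta to a large group (((dichloromethyl)carbonyl)amino in place of chloro on an aromatic carbon). The nearest evidence comes from changes at that same carbon: an at least 2.0-fold lower number from compound 1 to compound 2 (0.31 log units; beyond the scatter), an at least 2.0-fold higher number from compound 2 to compound 3 (0.31 log units; beyond the scatter) and a step that the two limits leave unreadable from compound 1 to compound 3. None of these steps introduces the entering group, so the guide is weak. A modest move to a lower number is expected, estimated as an at least 1.6-fold lower number from compound 3 to compound 4 (0.22 log units; that floor lies within the scatter). In this assay, compound 4 is expected at 30000 nM, within an estimated range of 10000 nM to 70000 nM.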

Compound 4, half-maximal inhibitory concentration: > 50000 nM
Compound 4: a limit, no number; the forecaster's own chance of this, stated with the estimate: 45%; at least 1.6-fold (0.22 log units) between middle value and limit.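

In this assay compound 4 gives > 50000 nM as a limit of the assay. Replacing methyl with ((dichloromethyl)carbonyl)amino gives an at least 2.0-fold higher number from compound 2 to compound 4 (0.31 log units; beyond the scatter) at this aromatic carbon. Among the compounds shown here, the steps to compound 4 from compound 1 and compound 3 cannot be read, and methyl remains the only group here with a measured number, while the others share one limit: the limit of > 50000 nM in this assay, at which 3 of the 4 values shown sit.

Going by these compounds, whether an ethyl, a methoxy or a hydroxyl group on this carbon would give a measured number stays open. On these data alone, the order among compound 1, compound 3 and compound 4 also stays open.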